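The compounds below may be only part of what the source reports. "The series", "measured", "known", "first", "only" and "open" are said of these compounds alone.

Measured in a functional assay on A549 cells (Homo sapiens) for antiproliferative activity, read by MTT assay, with a stated time of 48 h; on this read-out lower numbers stand for stronger inhibition and higher numbers for weaker inhibition:

- compound 1 `COc1ccc(C(=O)c2ccc(OC)c3c2OC(C)(C)C=C3)c(NC(=O)CBr)c1`: 1210 nM
- compound 2 `COc1ccc(C(=O)c2ccc(OC)c3c2C=CC(C)(C)O3)c(NC(=O)CO)c1`: 100 nM
- compound 3 `COc1ccc(C(=O)c2ccc3c(c2)C=CC(C)(C)O3)c(NC(=O)CO)c1`: 90 nM

Compound 1 has the highest number of the three and so the weakest inhibition, clearly apart from both others. Compound 4 `CCNCC(=O)Nc1cc(OC)ccc1C(=O)c1ccc(OC)c2c1OC(C)(C)C=C2` keeps the core of compound 1 and changes one group: ethylamino in place of bromo on a saturated chain carbon bound to a carbonyl carbon. Among the compounds with values here, no measured pair isolates this change. Within the data shown here, the only hint is that compound 2 at 100 nM and compound 3 at 90 nM also lack bromo, though they differ from compound 1 elsewhere too. A moderate gain in this assay is therefore expected, with the estimated step being a 2.4-fold lower number from compound 1 to compound 4 (0.38 log units; beyond the scatter). For compound 4 the expected value is 500 nM, with an estimated range of 120 nM to 2500 nM.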

Compound 4, half-maximal inhibitory concentration: 1050 nM
For compound 4 the middle estimate is 2.1-fold (0.32 log units) below the measured one; the range from low to high includes it.
By their numbers in this assay, from the lowest: compounds 3 and 2 (each within the scatter of the next); then compounds 4 and 1 (each within the scatter of the next).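

In this assay, ethylamino in place of bromo on a saturated chain carbon bound to a carbonyl carbon gives a 1.2-fold lower number from compound 1 to compound 4 (0.06 log units; within the scatter) and so leaves the number within the scatter. At this position on the core of compound 1, bromo can thus be exchanged for ethylamino, with its added heavy atoms, hydrogen-bond donor and hydrogen-bond acceptor, without a discernible shift. No measurement at hand accounts for this outcome. The compounds shown leave open whether a dimethylamino group, a carboxylic acid or a longer chain at this carbon would move the number.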